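Chloro in place of methoxy on the aromatic ring

The source may hold more compounds than are shown below. What is called first, only, known or untested is meant among the compounds shown, and "the series" means these compounds.

In a physicochemical assay for lipophilicity, at pH 7.4 (on this read-out higher numbers stand for higher lipophilicity and lower numbers for lower lipophilicity), compound 3 `COc1ccc(C2(C(=O)N3CCC[C@@H]3C(=O)Nc3ccc4[nH]ncc4n3)CCC2)cc1` gives 3.9, level within the scatter with compound 2 `O=C(Nc1ccc2[nH]ncc2n1)[C@H]1CCCN1C(=O)C1(c2ccc(F)cc2)CCC1` at 4.1, while compound 1 `COc1ccc(NC(=O)[C@H]2CCCN2C(=O)C2(c3cccc(Cl)c3)CCCC2)nc1` gives 6.8, a gap beyond the scatter from both. Compound 4 `O=C(Nc1ccc2[nH]ncc2n1)[C@H]1CCCN1C(=O)C1(c2ccc(Cl)cc2)CCC1` carries chloro in place of methoxy on an aromatic carbon, para to a large group: chloro in place of methoxy on an aromatic carbon. For the measured compounds named here, the only measured step at this place, a number 0.20 log units lower from compound 2 to compound 3 (within the scatter), is small and involves no chloro. Compound 1, which also carries chloro, at 6.8 hints weakly upward, though its core differs. A modest upward step is therefore expected, estimated as a number 0.50 log units higher from compound 3 to compound 4 (beyond the scatter). For compound 4 the expected value is 4.4, with an estimated range of 4 to 4.8.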

Compound 4, distribution coefficient: 4.7
Compound 4: middle estimate off by 0.30 log units, on the low side, and the stated range covers the measured number.
By their numbers in this assay, from the lowest: compounds 3 and 2 (each within the scatter of the next); then compound 4; then compound 1.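

At this position, para to a large group, this assay separates chloro from methoxy (a number 0.80 log units higher from compound 3 to compound 4 (beyond the scatter)) and from fluoro (a number 0.60 log units higher from compound 2 to compound 4 (beyond the scatter)). The earlier pair showed no such separation between methoxy and fluoro (a number 0.20 log units lower from compound 2 to compound 3 (within the scatter)). Within these three compounds on the shared core, the read-out therefore responds to this position only with chloro in place.

From the compounds shown here alone, whether an amine or a carboxylic acid here would shift the number in either direction remains open, as does whether the chloro step carries over to the core of compound 1. No available evidence accounts for the step.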